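Chromenone thioethers: dropping the chloro of compound 3

The source may report more compounds than this note shows. Statements on the series, on what has been measured and on what is new or still open speak of the compounds shown alone.

Working notes on the series. Compound 1 `Cc1nnc(SCc2cc(=O)c3ccccc3o2)o1` gives no number in a functional assay on MDA-MB-435S cells (Homo sapiens) for cytotoxicity, read by MTT assay, with a stated time of 72 h; on this read-out higher numbers stand for weaker inhibition and lower numbers for stronger inhibition: for compound 1 the result is a limit of the assay, > 25000 nM. For compound 2 `O=c1cc(CSc2nc3ccccc3s2)oc2ccc(Cl)cc12` the result in this assay is likewise only a limit, > 25000 nM. Compound 3 `Cc1nnc(SCc2cc(=O)c3cc(Cl)ccc3o2)s1` stands in the same place: in this assay compound 3 gives only a limit, > 25000 nM. Every value shown sits at the limit of > 25000 nM in this assay, at which 3 of the 3 values shown sit. Compound 4 `Cc1nnc(SCc2cc(=O)c3ccccc3o2)s1` differs from compound 3 by hydrogen in place of chloro on an aromatic carbon. Among the compounds with values here, no step between measured compounds is available. Compound 1, which also lacks the chloro, sits at the limit with > 25000 nM. The step expected is therefore a step that the limit leaves unreadable from compound 3 to compound 4, none beyond the scatter. Compound 4 is expected to give 40000 nM in this assay, within 20000 nM to 120000 nM, most likely reported again as a limit.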

Compound 4, half-maximal inhibitory concentration: > 25000 nM
Compound 4: only a limit was reported; the forecaster's own chance of this, stated with the estimate: 85%; the middle value does not contradict the limit.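

No step can be read from compound 3 or from compound 1 to compound 4: all three give only a limit. The compounds shown leave open whether swapping chloro for hydrogen, or 5-methyl-1,3,4-oxadiazol-2-yl for 5-methyl-1,3,4-thiadiazol-2-yl, changes anything in this assay at all.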